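Extending the Amine Chain Once More

The compounds below may be only part of what the source reports. "The series", "measured", "known", "first", "only" and "open" are said of these compounds alone.

In a toxicity assay on CHO cells (Cricetulus griseus) for cytotoxicity, read by WST assay, with a stated time of 24 h (a lower number here means a stronger inhibitor, a higher number a weaker inhibitor), compound 1 `CC(C)=CCCC(C)=CCNCCN` gives 36200 nM. Compound 2 `CC(C)=CCCC(C)=CCNCCNCCNCCN` gives > 150000 nM, which is a limit of the assay and not a number. Its exact position is therefore unknown. Compound 3 `CC(C)=CCCC(C)=CCNCCNCCNCCNCCNCCN` carries the chain further: 2-((2-aminoethyl)amino)ethyl in place of hydrogen on an amine nitrogen. Within the data shown here, the one measured step that bears on this is the same swap, and it gave an at least 4.1-fold higher number from compound 1 to compound 2 (0.61 log units; beyond the scatter), which is beyond the scatter. A single step is thin ground, but it points towards a further rise in the number, meaning a weaker inhibitor in this assay. The expected change is modest, and it is estimated as a step that the limit leaves unreadable from compound 2 to compound 3. Compound 3 may well return only a limit too. As a number, compound 3 is expected at 220000 nM, within an estimated range of 90000 nM to 500000 nM.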

Compound 3, half-maximal inhibitory concentration: > 150000 nM
Compound 3 was reported as a limit (the forecaster's own chance of this, stated with the estimate: 70%); the middle value does not contradict the limit.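

No step can be read from compound 2 to compound 3 in this assay, since each result is a limit of the assay and not a number: the limit of > 150000 nM in this assay, at which 2 of the 3 values shown sit.

From the compounds shown here alone, how far the true values of compound 2 and compound 3 lie past that limit, and whether they differ at all, stays open.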